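The source may report more compounds than this note shows. Statements on the series, on what has been measured and on what is new or still open speak of the compounds shown alone.

Measured compounds:
compound 1, `O=C(Nc1nc2ccc(Oc3ccc(F)c(NCc4cccc(C(F)(F)F)c4)c3)cc2s1)C1CC1`, "not determined" (no result reported) in an assay for binding affinity to receptor-interacting serine/threonine-protein kinase 3 (Homo sapiens), read by KINOMEscan and polymerase chain reaction, with a stated time of 1 h; a lower number here means tighter binding, a higher number weaker binding
compound 2, `CC(=O)c1cccc(NC(=O)Nc2cc(Oc3ccc4nc(NC(=O)C5CC5)sc4c3)ccc2F)c1`, 53 nM

Two compounds share the core and differ at the outer aryl ring. For compound 1 no number was obtained in this assay, so it gives no foothold. Compound 2 is therefore the only measured point, with a dissociation constant of 53 nM in this assay; it stands alone, and nothing can be said of its rank against the other entry.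

Compound 3, `O=C(Nc1cccc(Br)c1)Nc1cc(Oc2ccc3nc(NC(=O)C4CC4)sc3c2)ccc1F`, is not yet measured. It differs from compound 2 in one place: bromo in place of acetyl on an aromatic carbon.

Among the compounds with values here, since no step between measured compounds is available, the expected size of the change from compound 2 to compound 3 in this assay can rest only on the single value of compound 2, 53 nM, and on the swap itself. Compound 3 is expected to stay close to compound 2, with a step of a 1.1-fold higher number from compound 2 to compound 3 (0.05 log units; within the scatter) that is not expected to exceed the usual scatter in either direction. Compound 3 is thus estimated at 60 nM, within a range of 20 nM to 180 nM.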

Compound 3, dissociation constant: 81 nM
Compound 3: the middle estimate sits 1.4-fold (0.13 log units) below what was measured; the measured number falls inside the stated range.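

In this assay, the exchange of 3-acetylphenyl for 3-bromophenyl gives a 1.5-fold higher number from compound 2 to compound 3 (0.18 log units; within the scatter), so the two compounds cannot be told apart by this read-out. Within the data shown here, this is the first readable step at this place on the outer ring, an aromatic carbon meta to a large group, and it spans a real difference in make-up: acetyl has three heavy atoms, a double bond and a hydrogen-bond acceptor, whereas bromo has one heavy atom and no acceptor, yet the two values still lie within the scatter of each other. No measurement at hand bears on why these two values lie so close together.

As far as these compounds go, whether this place would give a similarly small step with an amine, a carboxylic acid, a methoxy group or a longer alkyl chain remains open, since one step between two substituents cannot define a trend. Steps involving compound 1 cannot be read, so what its (3-trifluoromethylphenyl)methylamino-type outer arm does to binding also stays open.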